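Swapping Methyl for Chloro at the Assay Limit

The source may report more compounds than this note shows. Statements on the series, on what has been measured and on what is new or still open speak of the compounds shown alone.

Compound 1 `CCC(=O)N(c1ccc(Cl)c(Cl)c1)C1CCCC1O` gives 20 mg/kg as a measured number.
Compound 2 `CCC(=O)N(c1ccc(OC)cc1)C1CCCCC1N(C)C` gives > 50 mg/kg as a limit.
Compound 3 `CCC(=O)N(c1ccccc1C)C1CCCC1N(C)C` gives > 50 mg/kg as a limit.

In a functional assay on the whole organism for positive allosteric modulation, with Mus musculus as the target (on this read-out higher numbers stand for an effect only at larger amounts of compound and lower numbers for an effect already at smaller amounts), compound 3 gives > 50 mg/kg as a limit and not as an exact number. It therefore stands at the limit of > 50 mg/kg in this assay, at which 2 of the 3 values shown sit, and has no exact place on the scale. Only compound 1 has a true number, and it differs from compound 3 in more than one place, so it offers little guidance here.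

Compound 4 (`CCC(=O)N(c1ccccc1Cl)C1CCCC1N(C)C`) is compound 3 with chloro in place of methyl on an aromatic carbon, ortho to a large group (chloro in place of methyl on an aromatic carbon). Among the compounds with values here, no measured pair of compounds shows what this exchange does. Within the data shown here, the one firm guide is compound 3 itself, whose > 50 mg/kg is again only a limit. The expected outcome is no shift beyond the usual scatter, and the estimated change is a step that the limit leaves unreadable from compound 3 to compound 4 in this assay on this thin evidence. For compound 4 the estimate is 60 mg/kg with an expected range from 25 mg/kg to 150 mg/kg and a real chance of another limit.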

Compound 4, dose for half-maximal effect: > 50 mg/kg
Compound 4 ended at the assay's limit; the forecaster's own chance of this, stated with the estimate: 60%; the middle value lies beyond the limit too.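

Compound 3 and compound 4 both end at a limit and not at an exact number in this assay, so no step can be read between them; they sit at the same mark: the limit of > 50 mg/kg in this assay, at which 3 of the 4 values shown sit. The compounds shown leave open whether chloro in place of methyl on this aromatic carbon changes the dose needed at all.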